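Aryl imine replacing a sulfonylhydrazone on an oxindole core

The compounds below may be only part of what the source reports. "The series", "measured", "known", "first", "only" and "open" are said of these compounds alone.

Measured compounds:
compound 1 `O=C1Nc2ccc(S(=O)(=O)N3CCOCC3)cc2/C1=N/NS(=O)(=O)c1ccccc1`: 13300 nM
compound 2 `O=C1Nc2ccc(S(=O)(=O)N3CCOCC3)cc2/C1=N/c1ccc(/N=C2\C(=O)Nc3ccc(S(=O)(=O)N4CCOCC4)cc32)cc1`: 7480 nM

In a functional assay on HCT-116 cells (Homo sapiens) for cytotoxicity, read by sulforhodamine B assay, with a stated time of 24 h (on this read-out lower numbers stand for stronger inhibition and higher numbers for weaker inhibition), compound 1 gives 13300 nM, the higher of the two numbers recorded. Compound 2, a symmetrical pair of the shared core, gives 7480 nM in this assay, and the two values lie within the scatter of each other, so neither can be called stronger. Compound 3 `Cc1ccc(/N=C2\C(=O)Nc3ccc(S(=O)(=O)N4CCOCC4)cc32)cc1` has not yet been measured in this assay. It differs from compound 1 by 4-methylphenyl in place of (phenylsulfonyl)amino on a double-bonded nitrogen. Among the compounds with values here, no step between measured compounds exists to guide the size of this change, so the expectation rests on compound 1 alone. Compound 3 is therefore estimated at 10000 nM, with a range from 3000 nM to 33000 nM. The expected step of a 1.3-fold lower number from compound 1 to compound 3 (0.12 log units; within the scatter) is thought to stay within the scatter, with no clear direction.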

Compound 3, half-maximal inhibitory concentration: 18900 nM
For compound 3 the middle estimate is 1.9-fold (0.28 log units) below the measured one, and the stated range covers the measured number.
By their numbers in this assay, from the lowest: compounds 2, 1 and 3 (each within the scatter of the next, the first and the last beyond it).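

In this assay the exchange of (phenylsulfonyl)amino for 4-methylphenyl on a double-bonded nitrogen gives a 1.4-fold higher number from compound 1 to compound 3 (0.15 log units; within the scatter), so compound 1 and compound 3 cannot be told apart. At this position, then, the sulfonyl-bearing link can give way to a directly attached aromatic ring of carbon without a difference beyond the scatter. No measurement at hand accounts for this result. The compounds shown leave open whether a carboxylic acid or an amine on that ring in place of the methyl would separate from compound 3.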